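Aryl exchange on the shared core: compound 3 to compound 4

The source may report more compounds than this note shows. Statements on the series, on what has been measured and on what is new or still open speak of the compounds shown alone.

Compound 3 `CCOc1ncc(-c2nc(C(F)(F)F)sc2N2CCN(C(=O)Cn3nc(C)nc3C)[C@H](C)C2)cn1` sits alongside compound 1 `CCOc1ncc(-c2nc(C(F)(F)F)sc2N2CCN(C(=O)Cn3c(=O)oc4ccccc43)[C@H](C)C2)cn1` and compound 2 `CCOc1ncc(-c2nc(C(F)(F)F)sc2N2CCN(C(=O)Cn3nccc3C)[C@H](C)C2)cn1`, all three sharing the same core and differing only in the group on the saturated chain carbon bound to the carbonyl carbon. In a functional assay on U2OS cells for antagonist activity at C-X-C chemokine receptor type 3 (Homo sapiens), read by beta-arrestin recruitment (a higher number here means a weaker inhibitor, a lower number a stronger inhibitor), compound 3 gives 173 nM; compound 2 gives 162 nM and compound 1 gives 99 nM. The steps of a 1.7-fold higher number from compound 1 to compound 3 (0.24 log units; within the scatter) and a 1.1-fold higher number from compound 2 to compound 3 (0.03 log units; within the scatter) both fall within the scatter, as does a 1.6-fold higher number from compound 1 to compound 2 (0.21 log units; within the scatter), so the three numbers are not separated from one another.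

Compound 4 `Cc1nc(C)n(CC(=O)N2CCN(c3sc(C(F)(F)F)nc3-c3ccc(C(F)(F)F)nc3)C[C@H]2C)n1` differs from compound 3 by 6-(trifluoromethyl)pyridin-3-yl in place of 2-ethoxypyrimidin-5-yl on an aromatic carbon. The three measured steps all exchange the group on the saturated chain carbon bound to the carbonyl carbon and leave the aromatic carbon of the shared core untouched; none of them bears on this change. Within the data shown here, with no measured step for the exchange itself, the expectation rests only on the narrow spread of the three numbers: the estimated step of a 1.2-fold higher number from compound 3 to compound 4 (0.06 log units; within the scatter) is set near zero and carries a wide range. Compound 4 is expected to give 200 nM, between 60 nM and 700 nM.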

Compound 4, half-maximal inhibitory concentration: 608 nM
Estimate against measurement, compound 4: 3.0-fold (0.48 log units) below; low and high end bracket the measured number.
By their numbers in this assay, from the lowest: compounds 1, 2 and 3 (each within the scatter of the next); then compound 4.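

In this assay, among these compounds, the aromatic carbon of the shared core proves sensitive to the aryl group it carries: a 3.5-fold higher number from compound 3 to compound 4 (0.55 log units; beyond the scatter) is the only step so far beyond the scatter, whereas all three exchanges on the saturated chain carbon stay within it. With the substituent on the carbonyl-linked chain held as in compound 3, 6-(trifluoromethyl)pyridin-3-yl therefore gives a modest loss against 2-ethoxypyrimidin-5-yl. Nothing available explains this step.

From the compounds shown here alone, this one exchange alters the ring and its substituent together, so the share of each in the step cannot be separated, and whether the same step holds with the groups of compound 1 or compound 2 stays open. Also open, going by these compounds, is how an amine or a longer alkoxy chain in place of the ethoxy group would read in this assay.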